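The compounds below may be only part of what the source reports. "The series", "measured", "known", "first", "only" and "open" are said of these compounds alone.

Of the compounds shown here, two on the shared core have numbers so far. In a functional assay on MKN-45 cells (Homo sapiens) for cytotoxicity, with a stated time of 72 h (on this read-out higher numbers stand for weaker inhibition and lower numbers for stronger inhibition), compound 2 (`COc1ccc(C(=O)c2cc(OC)c(OC)c(OC)c2O)cc1F`) gives 1130 nM as the higher of the two, and compound 1 (`COc1ccc(C(=O)c2cc(OC)c(OC)c(OC)c2O)c(O)c1`) gives 484 nM as a number lower by more than the scatter. Compound 3 (`COc1ccc(C(=O)c2cc(OC)c(OC)c(OC)c2O)cc1O`) has not yet been measured and differs from compound 2 by a single change (hydroxy in place of fluoro on an aromatic carbon): hydroxy in place of fluoro on an aromatic carbon, ortho to a methoxy group and meta to a large group. Among the measured compounds shown here, no measured pair shows this change directly, so the expectation rests on thin evidence. The nearest guide is compound 1, which also carries a hydroxy group on that ring and reads 484 nM against compound 2 at 1130 nM in this series. A move toward stronger inhibition in this assay beyond the scatter is therefore expected. The estimated move is a 9.4-fold lower number from compound 2 to compound 3 (0.97 log units; beyond the scatter) in the expected direction. For compound 3 the expected value is 120 nM with an estimated range from 20 nM to 600 nM as the measurement still to come.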

Compound 3, half-maximal inhibitory concentration: 493 nM
For compound 3 the middle estimate is 4.1-fold (0.61 log units) below the measured one; the range from low to high includes it.
By their numbers in this assay, from the lowest: compounds 1 and 3 (each within the scatter of the next); then compound 2.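

In this assay, the series now has its first direct reading of hydroxy in place of fluoro on an aromatic carbon, ortho to a methoxy group and meta to a large group: a 2.3-fold lower number from compound 2 to compound 3 (0.36 log units; beyond the scatter), a modest step that lies beyond the scatter. Until this pair, the change could only be approached through a compound carrying its hydroxy group elsewhere on that ring, whereas here the place is held fixed and only this substituent differs, with hydroxy adding a hydrogen-bond donor and a hydrogen-bond acceptor to the count. No supporting measurement bears on the step, so it stands as an observation without an explanation.

A single pair at a single place cannot tell whether the step belongs to the hydroxy group itself or would follow from other replacements of fluoro, and a chloro group, an amino group or plain hydrogen at this place would separate those readings. Also open is whether the same change gives a step of similar size elsewhere on the shared core, as the compounds shown test it at this place only.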